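Pyridazinyl piperazine ureas: trifluoromethoxy in place of isopropyl

The source may report more compounds than this note shows. Statements on the series, on what has been measured and on what is new or still open speak of the compounds shown alone.

Working notes on the series. Compound 1 `Cc1ccc(N2CCN(C(=O)Nc3ccc(C(C)C)cc3)CC2)nn1` carries an isopropyl on the six-membered aromatic ring of carbon only and a 6-methylpyridazin-3-yl on the amine nitrogen in a ring; compound 2 `Cc1ccc(N2CCN(C(=O)Nc3ccc(OC(F)(F)F)cc3)CC2)nn1` carries a trifluoromethoxy instead of the isopropyl; compound 3 `Cc1cc(N2CCN(C(=O)Nc3ccc(C(C)C)cc3)CC2)nnc1Cl` keeps the isopropyl but carries a 6-chloro-5-methylpyridazin-3-yl on the amine nitrogen in a ring. In an assay on HEK293 cells for inhibition of transient receptor potential cation channel subfamily V member 1 (Homo sapiens), read by FLIPR (on this read-out higher numbers stand for weaker inhibition and lower numbers for stronger inhibition), compound 1 gives only a limit, > 10000 nM. In this assay compound 2 likewise gives only a limit, > 10000 nM. Compound 3 stands at the same limit in this assay, > 10000 nM, so nothing places it above or below its neighbours. Both measured steps, a step that the two limits leave unreadable from compound 1 to compound 2 and a step that the two limits leave unreadable from compound 1 to compound 3, are unreadable because of the limit of > 10000 nM in this assay, at which 3 of the 3 values shown sit. Compound 4 `Cc1cc(N2CCN(C(=O)Nc3ccc(OC(F)(F)F)cc3)CC2)nnc1Cl` differs from compound 3 by trifluoromethoxy in place of isopropyl on an aromatic carbon. The same swap, from compound 1 to compound 2, gave no readable step, so for compound 4 the expected change in this assay is a step that the limit leaves unreadable from compound 3 to compound 4, that is, none that can be read. Compound 4 is therefore estimated at 15000 nM, most probably again a limit, in the range 7000 nM to 40000 nM.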

Compound 4, half-maximal inhibitory concentration: > 10000 nM
Compound 4 was reported as a limit (the forecaster's own chance of this, stated with the estimate: 85%); the middle value lies beyond the limit too.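

The steps to compound 4 from compound 3 and from compound 2 cannot be read in this assay, because of a single limit: the limit of > 10000 nM in this assay, at which 4 of the 4 values shown sit.

The compounds shown leave open whether trifluoromethoxy or 6-chloro-5-methylpyridazin-3-yl changes inhibition at all, and how far any of the four compounds lies from that limit.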